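The source may report more compounds than this note shows. Statements on the series, on what has been measured and on what is new or still open speak of the compounds shown alone.

Of the compounds shown here, three have so far been measured in a physicochemical assay for lipophilicity; a lower number here means a more polar compound, a higher number a more lipophilic compound. Compound 1 `O=C(O)c1cncc(C2=C(c3cc(Cl)ccc3OCc3ccc(F)cc3F)CCC2)n1` gives 1.6, compound 3 `O=C(O)c1cncc(C2=C(c3cc(C(F)(F)F)ccc3OCc3ccccc3)CCC2)c1` gives 2.7, and compound 2 `O=C(O)c1cc(C2=C(c3cc(Cl)ccc3OCc3ccccc3)CCC2)ncn1` gives 1.2, the lowest of the three numbers, with compound 1 and compound 3 both lying beyond the scatter above it. Compound 4 `O=C(O)c1ccnc(C2=C(c3cc(Cl)ccc3OCc3ccccc3)CCC2)n1` has the same atoms as compound 2, joined differently: 4-carboxypyrimidin-2-yl in place of 6-carboxypyrimidin-4-yl on a double-bonded ring carbon. Going by the values given here, no step between measured compounds of this kind is available, so only a small shift in this assay is expected for this rearrangement, in either direction, and most likely none beyond the scatter. Compound 4 is therefore estimated at 1.3, with a range from 0.9 to 1.8, and the step expected from compound 2 to compound 4 is a number 0.10 log units higher from compound 2 to compound 4 (within the scatter).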

Compound 4, distribution coefficient: 0.8
For compound 4 the middle estimate is 0.50 log units above the measured one; measured number outside the range, below it.
By their numbers in this assay, from the lowest: compound 4; then compound 2; then compound 1; then compound 3.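

In this assay, 4-carboxypyrimidin-2-yl in place of 6-carboxypyrimidin-4-yl on a double-bonded ring carbon gives a number 0.40 log units lower from compound 2 to compound 4 (beyond the scatter). Going by these compounds alone, this is the first single-place comparison, and it shows that rejoining the same atoms, with the counted donors and acceptors unchanged, can shift the number beyond the scatter. No measured information accounts for the shift.

The compounds shown leave open whether this step recurs with trifluoromethyl in place of the chlorine. They also leave open how a tetrazole or an amide in place of the carboxylic acid would read at this position.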